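Working notes: from compound 2 to compound 3

The compounds below may be only part of what the source reports. "The series", "measured", "known", "first", "only" and "open" are said of these compounds alone.

- compound 1 `CNc1nc(SCc2nc3ccccc3[nH]2)nc(-c2ccccc2)c1C#N`: 3 nM
- compound 2 `N#Cc1c(Nc2nccs2)nc(SCc2nc3ccccc3[nH]2)nc1-c1ccccc1`: 5.81 nM

Both values come from a functional assay on SK-OV-3 cells (Homo sapiens) for cytotoxicity, read by MTT assay, with a stated time of 3 days; on this read-out lower numbers stand for stronger inhibition and higher numbers for weaker inhibition. Compound 2 lies within the scatter of compound 1. Compound 3 `N#Cc1c(NC(N)=O)nc(SCc2nc3ccccc3[nH]2)nc1-c1ccccc1` differs from compound 2 by carbamoyl in place of 1,3-thiazol-2-yl on a nitrogen on an aromatic ring. Going by the values given here, only one measured step bears on this change, a 1.9-fold higher number from compound 1 to compound 2 (0.29 log units; within the scatter), which also exchanged the group on that nitrogen. Among the compounds with values here, it is a single step, and no measured compound carries carbamoyl, so the range is kept wide. No shift beyond the scatter is expected in this assay, in either direction. The expected change is a 1.0-fold higher number from compound 2 to compound 3 (0.01 log units; within the scatter). Compound 3 is estimated at 6 nM, with an expected range from 2 nM to 20 nM.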

Compound 3, half-maximal inhibitory concentration: 6.75 nM
The estimate for compound 3 lay 1.1-fold (0.05 log units) below the measured number; the measured number falls inside the stated range.
By their numbers in this assay, from the lowest: compounds 1, 2 and 3 (each within the scatter of the next, the first and the last beyond it).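

On the nitrogen on an aromatic ring, carbamoyl, which has no ring, sits with 1,3-thiazol-2-yl in this assay (a 1.2-fold higher number from compound 2 to compound 3 (0.07 log units; within the scatter)), so this position accepts the loss of the aromatic ring with no change beyond the scatter. Set against methyl, the same carbamoyl gives the only step in the series that clears the scatter (a 2.3-fold higher number from compound 1 to compound 3 (0.35 log units; beyond the scatter)), and that step is modest, while compound 1 and compound 2 remain within the scatter of each other. No supporting data bear on why these three groups lie so close together.

On these data alone, whether a plain amine on that nitrogen, or an acetyl group or a longer chain such as butyl, stays in the same range remains open. Also open, as far as these compounds go, is whether a carboxylic acid at this place would keep the series this flat.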